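A few compounds are considered here, and "the series" means these few. Any claim that something is new, unique, unknown or untested is made for them only; others in the source may bear on it.

Compound 1, `CC(C(=O)NCc1ccc(C(F)(F)F)cc1N1CCN(C2CCCCC2)CC1)c1ccc(NS(C)(=O)=O)c(F)c1`: 13.8 nM in an assay on CHO cells for antagonist activity at transient receptor potential cation channel subfamily V member 1 (Homo sapiens), read by FLIPR; on this read-out higher numbers stand for weaker inhibition and lower numbers for stronger inhibition
Compound 2, `CCCCCc1cc(C(F)(F)F)ccc1CNC(=O)C(C)c1ccc(NS(C)(=O)=O)c(F)c1`: 0.4 nM in this assay

Of these two, compound 1 stands at the higher, weaker number; the only comparison shown, a 35-fold lower number from compound 1 to compound 2 (1.54 log units; beyond the scatter), places compound 2 far ahead of it.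

Compound 3, `CC(C(=O)NCc1ccc(C(F)(F)F)cc1-c1ccc(C(C)(C)C)cc1)c1ccc(NS(C)(=O)=O)c(F)c1`, has not yet been tested. Compared with compound 1 the change is 4-(tert-butyl)phenyl in place of 4-cyclohexylpiperazin-1-yl on an aromatic carbon. Among the compounds with values here, the one step that bears on this is the same exchange of the group at this aromatic carbon, where a 35-fold lower number from compound 1 to compound 2 (1.54 log units; beyond the scatter): removing the 4-cyclohexylpiperazin-1-yl group and putting a plain carbon-only group in its place gave a much stronger result. The 4-(tert-butyl)phenyl group is likewise carbon-only, so a similar gain is expected, though its size is uncertain with one precedent.

Compound 3 is therefore estimated at 1.5 nM in this assay, with a range of 0.3 nM to 8 nM, an expected step of a 9.2-fold lower number from compound 1 to compound 3 (0.96 log units; beyond the scatter).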

Compound 3, inhibition constant: 1.1 nM
Compound 3: middle estimate off by 1.4-fold (0.13 log units), on the high side; the measured number falls inside the stated range.
By their numbers in this assay, from the lowest: compound 2; then compound 3; then compound 1.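

In this assay, a second carbon-only group at this aromatic carbon also outperforms the 4-cyclohexylpiperazin-1-yl group, with a 13-fold lower number from compound 1 to compound 3 (1.10 log units; beyond the scatter) in the measured number, so the gain is not limited to the pentyl chain and also appears with a group carrying a six-membered aromatic ring. The two carbon-only groups are still not interchangeable: putting 4-(tert-butyl)phenyl in place of pentyl gives a 2.8-fold higher number from compound 2 to compound 3 (0.44 log units; beyond the scatter) as a modest step, which leaves pentyl ahead of the bulkier-named aryl group in this pair. Nothing measured here explains these differences.

The compounds shown leave open how a plain phenyl ring or a shorter propyl chain would fare at this carbon. They also leave open whether a morpholine ring, or a piperazine without its cyclohexyl group, would recover any of the lost strength.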